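The source may report more compounds than this note shows. Statements on the series, on what has been measured and on what is new or still open speak of the compounds shown alone.

Measured in an ADME assay on cells (Epithelial cell, Rattus norvegicus) for cytotoxicity, read by MTT assay; a lower number here means a stronger inhibitor, a higher number a weaker inhibitor:

- compound 1 `O=C(Cn1c(=O)c(Cc2ccccc2)nc2ccccc21)NNC(=S)Nc1ccccc1` gives 16.1 nM
- compound 2 `Nn1c(Cn2c(=O)c(Cc3ccccc3)nc3ccccc32)nnc1Cn1c(=O)c(Cc2ccccc2)nc2ccccc21` gives 6.04 nM
- compound 3 `O=C(Cn1c(=O)c(Cc2ccccc2)nc2ccccc21)NN=c1c(=O)c2ccccc2c1=O` gives 7.98 nM

Compound 1 gives 16.1 nM, which lies within the usual scatter of compound 3 at 7.98 nM. Compound 2 at 6.04 nM shows a lower number than compound 1, and that gap is beyond the scatter.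

The next compound to be tested is compound 4 `Cc1ccc(C(=O)NNC(=O)Cn2c(=O)c(Cc3ccccc3)nc3ccccc32)cc1`. It keeps the core of compound 1 and changes one group on an amine nitrogen, where (4-methylphenyl)carbonyl enters: a group of 9 heavy atoms (8 carbon, 1 oxygen; one six-membered aromatic ring of carbon only) in place of a group of 9 heavy atoms (7 carbon, 1 nitrogen, 1 sulfur; one six-membered aromatic ring of carbon only), on an amine nitrogen.

Going by the values given here, no measured pair differs in one place, so the data offer no direct precedent for this change. The three measured compounds carry quite different groups, yet compound 2 at 6.04 nM and compound 3 at 7.98 nM stay close to compound 1. A step beyond the scatter in this assay is therefore not expected, only a slight drift toward a lower number. The expected step is a 1.6-fold lower number from compound 1 to compound 4 (0.21 log units; within the scatter), which is an estimate. For compound 4 the estimated value is 10 nM, with an expected range from 4 nM to 25 nM.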

Compound 4, half-maximal inhibitory concentration: 49.7 nM
Estimate against measurement, compound 4: 5.0-fold (0.70 log units) below; measured number outside the range, above it.
By their numbers in this assay, from the lowest: compounds 2, 3 and 1 (each within the scatter of the next, the first and the last beyond it); then compound 4.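

In this assay, going by these compounds alone, the swap on the amine nitrogen gives the first step in this set that can be read at a single place: (4-methylphenyl)carbonyl entering brings a 3.1-fold higher number from compound 1 to compound 4 (0.49 log units; beyond the scatter). Both groups have the same number of heavy atoms and one six-membered aromatic ring of carbon only, so the read-out at this position responds even when those features stay the same and the groups differ in their other atoms and in hydrogen-bond donors. No measurement here bears on the reason for this step.

A single step cannot separate the part played by the carbonyl from that of the methyl on the ring or of the atoms that leave. As far as these compounds go, how a plain acetyl group, or a chain ending in a carboxylic acid, would read on the same amine nitrogen remains open.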